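Removing the Amino Group from the Pendant Phenyl

The compounds below may be only part of what the source reports. "The series", "measured", "known", "first", "only" and "open" are said of these compounds alone.

Three compounds built on one shared core were measured in a functional assay, read by spectrophotometry, with a stated time of 30 min; on this read-out higher numbers stand for weaker inhibition and lower numbers for stronger inhibition. Compound 1 `Cc1nc2c3ccccc3ccc2c2nc3c(ccc4ccccc43)c(-c3cc([N+](=O)[O-])ccc3N)c12` gives 93.1 ug/mL, compound 2 `Cc1nc2c3ccccc3ccc2c2nc3c(ccc4ccccc43)c(-c3ccccc3N)c12` gives 95.4 ug/mL, and compound 3 `Cc1nc2c3ccccc3ccc2c2nc3c(ccc4ccccc43)c(-c3ccc(O)cc3)c12` gives 86.4 ug/mL. Compound 2 holds the highest of the three numbers, yet the step of a 1.0-fold higher number from compound 1 to compound 2 (0.01 log units; within the scatter) and the step of a 1.1-fold lower number from compound 2 to compound 3 (0.04 log units; within the scatter) both lie within the scatter, as does the step of a 1.1-fold lower number from compound 1 to compound 3 (0.03 log units; within the scatter).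

Compound 4 `Cc1nc2c3ccccc3ccc2c2nc3c(ccc4ccccc43)c(-c3ccccc3)c12` has not yet been measured. It differs from compound 2 by hydrogen in place of amino on an aromatic carbon. Within the data shown here, no measured step removes the amino group on its own, but each change made so far on the phenyl, hydrogen in place of nitro and 4-hydroxyphenyl in place of 2-aminophenyl, left this assay unmoved beyond the scatter. The step from compound 2 to compound 4 is therefore expected to be a 1.0-fold lower number from compound 2 to compound 4 (0.01 log units; within the scatter), with no shift beyond the scatter in either direction. Compound 4 is estimated at 93 ug/mL, with a range from 60 ug/mL to 140 ug/mL.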

Compound 4, half-maximal inhibitory concentration: 164 ug/mL
Compound 4: the middle estimate sits 1.8-fold (0.25 log units) below what was measured; measured number outside the range, above it.
By their numbers in this assay, from the lowest: compounds 3, 1, 2 and 4 (each within the scatter of the next).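

In this assay, taking the amino group off the pendant phenyl gives a 1.7-fold higher number from compound 2 to compound 4 (0.24 log units; within the scatter) and does not separate the two compounds. Comparing the bare phenyl with the other two rings gives a 1.9-fold higher number from compound 3 to compound 4 (0.28 log units; within the scatter) and a 1.8-fold higher number from compound 1 to compound 4 (0.25 log units; within the scatter), so these are the widest steps yet seen at this position, but all of them stay within the scatter and the unsubstituted ring cannot be told apart from the rings carrying amino, nitro or hydroxy groups. Nothing available accounts for the size of these steps.

Still open, as far as these compounds go, is whether any group on this phenyl moves the number beyond the scatter, for example a carboxylic acid, a methoxy group, a chlorine atom or a longer alkyl chain. Also open, from the compounds shown here alone, is whether a replacement of the phenyl itself, by a pyridine ring or a simple methyl group, would do so.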